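The source may hold more compounds than are shown below. What is called first, only, known or untested is meant among the compounds shown, and "the series" means these compounds.

The series shares one core, carried by compound 1 `Cc1nc2c3ccccc3ccc2c2nc3c(ccc4ccccc43)c(-c3ccccc3N)c12`, compound 2 `Cc1nc2c3ccccc3ccc2c2nc3c(ccc4ccccc43)c(-c3ccccc3Cl)c12` and compound 3 `Cc1nc2c3ccccc3ccc2c2nc3c(ccc4ccccc43)c(-c3cc(O)nc4ccccc34)c12`, which differ only in the aryl group attached to that core. In a functional assay on HeLa cells (Homo sapiens) for cytotoxicity, read by MTT assay, with a stated time of 48 h (a higher number here means a weaker inhibitor, a lower number a stronger inhibitor), compound 1 gives 16200 nM. Compound 2 in this assay gives only a limit, > 80000 nM. For the measured compounds named here, the single measured step, an at least 4.9-fold higher number from compound 1 to compound 2 (0.69 log units; beyond the scatter), is the only movement seen so far; its size is bounded by the limit of > 80000 nM in this assay, at which 1 of the 2 values shown sits, so only a lower bound on the loss is known.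

Compound 3 carries 2-hydroxyquinolin-4-yl in place of 2-chlorophenyl on an aromatic carbon. Going by the values given here, the entering group brings hydrogen-bond donor and acceptor character, as the amino group of compound 1 does, while the chloro group of compound 2 brings none; the one measured step points to the donor-bearing compound 1 with 16200 nM as the stronger of the measured pair. On that basis the number for compound 3 is expected to fall back toward that of compound 1, with a step of an at least 4.0-fold lower number from compound 2 to compound 3 (0.60 log units; beyond the scatter) expected. Compound 3 is estimated at 20000 nM, with a range from 5000 nM to 70000 nM.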

Compound 3, half-maximal inhibitory concentration: 4880 nM
Compound 3: the middle estimate sits 4.1-fold (0.61 log units) above what was measured; measured number outside the range, below it.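

At the aromatic carbon opposite the ring nitrogen, the shift to 2-hydroxyquinolin-4-yl in this assay gives an at least 16-fold lower number from compound 2 to compound 3 (1.21 log units; beyond the scatter), so the loss seen with 2-chlorophenyl is more than recovered. The new group also improves on 2-aminophenyl, with a 3.3-fold lower number from compound 1 to compound 3 (0.52 log units; beyond the scatter), which makes compound 3 the strongest of the three and shows that this position can carry a group larger than a single substituted phenyl ring while the number still falls. The true size of the step from the chloro compound remains unknown, and only its lower bound can be read: the limit of > 80000 nM in this assay, at which 1 of the 3 values shown sits.

The compounds shown do not separate the contributions of the second aromatic ring, the ring nitrogen and the hydroxyl group within 2-hydroxyquinolin-4-yl, since compound 3 differs from compound 1 in all of these at once. Unsubstituted quinolin-4-yl, 2-methoxyquinolin-4-yl and 2-hydroxyphenyl at the same carbon would pull these parts apart, and whether the order of the three compounds holds on cells other than HeLa also stays open.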